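Hydrogen for methyl on an aromatic nitrogen: compound 4

This account rests on a few compounds, and the source may have more. Where it says the series, first, only, none or still open, it means among the compounds named here.

Measured so far in a functional assay on COLO 320 cells (Homo sapiens) for cytotoxicity, read by WST assay, with a stated time of 72 h; on this read-out lower numbers stand for stronger inhibition and higher numbers for weaker inhibition:
compound 1 `COc1ccc(-c2cc(-c3cc4ccccc4n3C)no2)cc1` gives > 100000 nM, a limit of the assay.
compound 2 `Cn1c(-c2cc(-c3ccc(F)cc3)no2)cc2ccccc21` gives > 100000 nM, a limit of the assay.
compound 3 `O=[N+]([O-])c1ccc(-c2cc(-c3ccc4[nH]ccc4c3)on2)cc1` gives 14000 nM.

Compound 1 stands at the limit of > 100000 nM in this assay, at which 2 of the 3 values shown sit; no number is known for it, only this limit. Compound 4 `COc1ccc(-c2cc(-c3cc4ccccc4[nH]3)no2)cc1` differs from compound 1 by hydrogen in place of methyl on an aromatic nitrogen. Among the compounds with values here, no step between measured compounds is available for this change. Compound 3 differs from compound 1 in several places at once, so that compound 3 reaches 14000 nM says little about this single change. The step is expected to be small, an at least 1.6-fold lower number from compound 1 to compound 4 (0.22 log units; that floor lies within the scatter), and no direction beyond the scatter is expected. Compound 4 is estimated at 60000 nM, with a range from 15000 nM to 250000 nM.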

Compound 4, half-maximal inhibitory concentration: > 100000 nM
Compound 4 ended at the assay's limit; the forecaster's own chance of this, stated with the estimate: 55%; middle value at least 1.6-fold (0.22 log units) away from the limit.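

Compound 1 and compound 4 both end at the limit of this assay, so the step between them cannot be read: the limit of > 100000 nM in this assay, at which 3 of the 4 values shown sit.

On these data alone, what hydrogen in place of methyl on an aromatic nitrogen does to a compound within the assay's measurable range remains open.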